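Working notes: shortening the chain of compound 2

The source may report more compounds than this note shows. Statements on the series, on what has been measured and on what is new or still open speak of the compounds shown alone.

Measured in a functional assay on PC-3 cells (Homo sapiens) for cytotoxicity; on this read-out lower numbers stand for stronger inhibition and higher numbers for weaker inhibition:
- compound 1 `COc1ccc2nc(NC(=O)CCCCC(=O)NO)sc2c1`: 15.3 ug/mL
- compound 2 `CS(=O)(=O)c1ccc2nc(NC(=O)CCCCCCC(=O)NO)sc2c1`: 5.69 ug/mL

Compound 2 holds the lower of the two numbers, and its gap to compound 1 lies beyond the scatter. Compound 3 `CS(=O)(=O)c1ccc2nc(NC(=O)CCCCC(=O)NO)sc2c1` differs from compound 2 by hydroxycarbamoyl in place of 2-(hydroxycarbamoyl)ethyl on a saturated chain carbon, four bonds along the chain from a carbonyl carbon, on a saturated chain carbon, four bonds along the chain from a carbonyl carbon. For the measured compounds named here, no measured step isolates this change. A moderate rise in this assay is expected, with compound 1 at 15.3 ug/mL as the only higher reference. The estimated change is a 1.6-fold higher number from compound 2 to compound 3 (0.20 log units; within the scatter). For compound 3 the expected value is 9 ug/mL, within an estimated range of 4 ug/mL to 20 ug/mL.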

Compound 3, half-maximal inhibitory concentration: > 30 ug/mL
Compound 3 was reported as a limit; the forecaster's own chance of this, stated with the estimate: 3%; middle value at least 3.3-fold (0.52 log units) away from the limit.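

At this chain position, hydroxycarbamoyl in place of 2-(hydroxycarbamoyl)ethyl gives an at least 5.2-fold higher number from compound 2 to compound 3 (0.72 log units; beyond the scatter) in this assay, so with methylsulfonyl on the core the shorter chain clearly raises the number. Methylsulfonyl in place of methoxy on an aromatic carbon gives an at least 1.9-fold higher number from compound 1 to compound 3 (0.29 log units; that floor lies within the scatter), so no gain from methylsulfonyl appears on the shorter chain, and that step has no firm size. Compound 3 stands at a limit of the assay and not at a number: the limit of > 30 ug/mL in this assay, at which 1 of the 3 values shown sits.

Open, as far as these compounds go, is how far past that limit compound 3 lies. Also open, from the compounds shown here alone, is whether a longer chain than that of compound 2, or an amine in place of methylsulfonyl, would lower the number.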